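This account rests on a few compounds, and the source may have more. Where it says the series, first, only, none or still open, it means among the compounds named here.

Measured compounds so far:
Compound 1 `c1ccc(Sc2ncnc3[nH]cnc23)cc1`: 0% in an assay on isolated protein for inhibition of Ca2+/calmodulin-dependent protein kinase II (CaM kinase II) (Rattus norvegicus), tested at 30 uM; on this read-out lower numbers stand for less inhibition and higher numbers for more inhibition at the one concentration tested (going by the name of the read-out)
Compound 2 `Fc1ccc(Sc2[nH]cnc3nccc2-3)cc1`: 3%
Compound 3 `c1ccc(-[n+]2c[nH]c3ncncc32)cc1`: 0%

Compound 3 stands level with compound 1 at the digits reported, the two together the lowest of the three numbers. Its nearest neighbour is compound 1, with no change at the digits reported; its furthest is compound 2, whose number is higher by an amount within the scatter. None of the three separates from the others beyond the scatter, so no ordering among them can be read from these numbers.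

Compound 4 `Fc1ccc(-[n+]2c[nH]c3ncncc32)cc1` has not yet been measured in this assay. It differs from compound 3 by fluoro in place of hydrogen on an aromatic carbon. Among the measured compounds shown here, no step between two measured compounds isolates this change. The only bearing on it comes from compound 2, which carries a fluoro on its six-membered aromatic ring of carbon only and gives 3%, a number that does not separate from compound 3 within the scatter. The expected step is therefore a number 1 percentage points higher from compound 3 to compound 4 (within the scatter), none beyond the scatter. Compound 4 is estimated at 1%, with a range from -8% to 10%.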

Compound 4, a percentage reported as inhibition, at one concentration (the size of the read-out at that concentration, not a potency): 0%
Compound 4: the middle estimate sits 1 percentage points above what was measured, and the stated range covers the measured number.
By their numbers in this assay, from the lowest: compounds 1, 3, 4 and 2 (each within the scatter of the next).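

In this assay, among the compounds shown here, the exchange of hydrogen for fluoro on an aromatic carbon, para to a group of 9 heavy atoms, gives no change at the digits printed from compound 3 to compound 4 (within the scatter) and provides the first single-place step. At this position, then, fluoro does not lift the charged core out of the range of the other compounds, a point that compound 2, which differs in more than one place, could not settle. No measurement at hand accounts for this outcome.

On these data alone, whether another group at this position, such as an amine, a carboxylic acid or a longer chain, would move the number remains open. Also open, as far as these compounds go, is what fluoro would do on a related compound showing clear inhibition, since this step starts from a compound with no inhibition recorded.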